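A few compounds are considered here, and "the series" means these few. Any claim that something is new, unique, unknown or untested is made for them only; others in the source may bear on it.

In an ADME assay on Caco-2 cells (Homo sapiens) for permeability, in the apical to basolateral direction (on this read-out lower numbers stand for lower permeability and higher numbers for higher permeability), compound 3 `Cn1cncc1CN1CC(N(CC2CCN(C(=O)N3CCCC3)CC2)S(=O)(=O)c2ccccn2)Cc2cc(C#N)ccc21` gives 0.6 10^-6 cm/s. In this assay compound 2 `CCNC(=O)N1CCC(CN(C2Cc3cc(C#N)ccc3N(Cc3cncn3C)C2)S(=O)(=O)c2ccccn2)CC1` gives 0.6 10^-6 cm/s, and in this assay compound 1 `CCC(=O)N1CCC(CN(C2Cc3cc(C#N)ccc3N(Cc3cncn3C)C2)S(=O)(=O)c2ccccn2)CC1` gives 0.5 10^-6 cm/s. Compound 3 thus shares the highest of the three numbers with compound 2, yet all three sit within the scatter of one another: no change at the digits printed from compound 2 to compound 3 (within the scatter), a 1.2-fold higher number from compound 1 to compound 3 (0.08 log units; within the scatter), and a 1.2-fold higher number from compound 1 to compound 2 (0.08 log units; within the scatter). Compound 4 `Cn1cncc1CN1CC(N(CC2CCN(C(=O)c3cccs3)CC2)S(=O)(=O)c2ccccn2)Cc2cc(C#N)ccc21` differs from compound 3 by thiophen-2-yl in place of pyrrolidin-1-yl on a carbonyl carbon. Going by the values given here, every measured step also changed the group on this carbonyl carbon, and none moved the number beyond the scatter; no measured step brought in an aromatic ring, so the data offer no direct guide for that part. Compound 4 is therefore expected to move little, if at all: a 1.3-fold higher number from compound 3 to compound 4 (0.12 log units; within the scatter). For compound 4 the estimate is 0.8 10^-6 cm/s, with a range from 0.3 10^-6 cm/s to 2 10^-6 cm/s.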

Compound 4, apparent permeability: 0.5 10^-6 cm/s
Compound 4: the middle estimate sits 1.6-fold (0.20 log units) above what was measured; the range from low to high includes it.
By their numbers in this assay, from the lowest: compounds 1, 4, 2 and 3 (each within the scatter of the next).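

In this assay, the carbonyl carbon now carries an aromatic ring, and thiophen-2-yl in place of pyrrolidin-1-yl stays within the scatter (a 1.2-fold lower number from compound 3 to compound 4 (0.08 log units; within the scatter)). Set against the other two groups, thiophen-2-yl also stays within the scatter (a 1.2-fold lower number from compound 2 to compound 4 (0.08 log units; within the scatter); no change at the digits printed from compound 1 to compound 4 (within the scatter)), so all four compounds remain level at this position, whether the group there is open-chain, saturated or aromatic. Nothing available accounts for this flat result.

Still open, as far as these compounds go, is whether a phenyl ring carrying a carboxylic acid, or an aminomethyl group, on this carbonyl carbon would move the number beyond the scatter. Also open, from the compounds shown here alone, is whether changes elsewhere on the shared core would do so.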